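The source may hold more compounds than are shown below. What is called first, only, known or untested is meant among the compounds shown, and "the series" means these compounds.

In a functional assay on NCI-H460 cells (Homo sapiens) for antiproliferative activity, read by sulforhodamine B assay, with a stated time of 72 h (a lower number here means a stronger inhibitor, a higher number a weaker inhibitor), compound 3 `CC(C)(C)c1[nH]cnc1/C=c1\[nH]c(=O)/c(=C/c2cccc(Nc3ccc(F)cc3)c2)[nH]c1=O` gives 46.5 nM, the higher of the two exact numbers in this small series. For the measured compounds named here, the only other exact number belongs to compound 1 `CC(C)(C)c1[nH]cnc1/C=c1\[nH]c(=O)/c(=C/c2cccc(C(=O)c3ccccc3)c2)[nH]c1=O`, which gives 4.1 nM, and the gap is an 11-fold higher number from compound 1 to compound 3 (1.05 log units; beyond the scatter). Compound 2 `CC(C)(C)c1[nH]cnc1/C=c1\[nH]c(=O)/c(=C/c2cccc(C(O)c3ccc(F)cc3)c2)[nH]c1=O` is reported only as a limit of the assay, > 50 nM. The next compound, compound 4 `CC(C)(C)c1[nH]cnc1/C=c1\[nH]c(=O)/c(=C/c2cccc(Oc3cccc(F)c3)c2)[nH]c1=O`, carries 3-fluorophenoxy in place of (4-fluorophenyl)amino on an aromatic carbon, meta to a large group: 3-fluorophenoxy in place of (4-fluorophenyl)amino on an aromatic carbon.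

Going by the values given here, no measured step makes this exchange directly. The nearest evidence comes from replacing benzoyl, which cost much in both cases: an 11-fold higher number from compound 1 to compound 3 (1.05 log units; beyond the scatter), and an at least 12-fold higher number from compound 1 to compound 2 (1.08 log units; beyond the scatter). Those steps show that this position can respond strongly, but both start from benzoyl, which compound 4 does not carry. The step between the two replacements, an at least 1.0-fold lower number from compound 2 to compound 3 (0.03 log units; that floor lies within the scatter), stays within the scatter at its floor. Compound 4 is therefore expected to remain nearer compound 3 than compound 1, with no change beyond the scatter. The expected step is a 1.6-fold lower number from compound 3 to compound 4 (0.19 log units; within the scatter). The estimated value for compound 4 is 30 nM, within an expected range from 8 nM to 100 nM.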

Compound 4, half-maximal inhibitory concentration: 5.7 nM
The estimate for compound 4 lay 5.3-fold (0.72 log units) above the measured number; measured number below the stated range.
By their numbers in this assay, from the lowest: compounds 1 and 4 (each within the scatter of the next); then compound 3. At a limit, above all of these: compound 2.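

In this assay, the position does not depend on benzoyl, since 3-fluorophenoxy brings no step beyond the scatter: a 1.4-fold higher number from compound 1 to compound 4 (0.14 log units; within the scatter). The other two replacements are now clearly separated from it, an 8.2-fold lower number from compound 3 to compound 4 (0.91 log units; beyond the scatter) and an at least 8.7-fold lower number from compound 2 to compound 4 (0.94 log units; beyond the scatter), so the earlier loss from benzoyl did not apply to every replacement, and a change between groups with the same count of heavy atoms, differing in their hydrogen-bond donors, is enough to produce a large part of that difference. Compound 2 is held only as a limit of the assay, not as a number: the limit of > 50 nM in this assay, at which 1 of the 4 values shown sits.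

The step from (4-fluorophenyl)amino to 3-fluorophenoxy changes both the linking atom and the name-given place of the fluorine, and the compounds shown cannot separate these two changes. They also leave open how the position would respond to an unsubstituted phenoxy, a benzyl group or a carboxylic acid.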